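The compounds below may be only part of what the source reports. "The series", "measured", "known", "first", "only" and "open" are said of these compounds alone.

Measured in an ADME assay on RAW264.7 cells (Mus musculus) for cytotoxicity, read by MTT assay, with a stated time of 72 h, tested at 50 uM; on this read-out higher numbers stand for a stronger effect at the one concentration tested and lower numbers for a weaker effect:

compound 1, `O=C(Cn1c(=O)oc2ccccc21)Nc1nc2ccccc2s1`: 43.5%
compound 2, `O=C(Cn1c(=O)oc2cc(Cl)ccc21)Nc1nc2ccccc2s1`: 38.7%
compound 3, `O=C(Cn1c(=O)oc2ccccc21)NCc1cccs1`: 23.4%

Compound 2 stands second highest of the three numbers. Its nearest neighbour is compound 1, and the step of a number 4.8 percentage points lower from compound 1 to compound 2 (within the scatter) lies within the scatter. For the measured compounds named here, its furthest is compound 3, whose value sits lower than that of compound 2 by more than the scatter allows; no single-point step links these two.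

Compound 4, `O=C(Cn1c(=O)oc2cc(Cl)ccc21)Nc1nc2ccc([N+](=O)[O-])cc2s1`, differs from compound 2 in one place: nitro in place of hydrogen on an aromatic carbon. Going by the values given here, the only measured step that bears on a substituent entering an aromatic carbon is a number 4.8 percentage points lower from compound 1 to compound 2 (within the scatter), which was within the scatter. Among the compounds with values here, no measured step covers a nitro group, so the expectation rests on that single chloro step alone. On that basis no step beyond the scatter is expected, and the estimated step is a number 1.3 percentage points higher from compound 2 to compound 4 (within the scatter). Compound 4 is therefore expected to give about 40% in this assay, with a range from 25% to 55%.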

Compound 4, a percentage reported as inhibition, at one concentration (the size of the read-out at that concentration, not a potency): 12.5%
The estimate for compound 4 lay 27.5 percentage points above the measured number; measured number outside the range, below it.
By their numbers in this assay, from the lowest: compound 4; then compound 3; then compounds 2 and 1 (each within the scatter of the next).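

In this assay nitro in place of hydrogen gives a number 26.2 percentage points lower from compound 2 to compound 4 (beyond the scatter) and so shows that a substituent entering an aromatic carbon can move this read-out beyond the scatter, which the chloro change, a number 4.8 percentage points lower from compound 1 to compound 2 (within the scatter), did not show. The read-out is therefore sensitive to nitro on this aromatic carbon of a six-membered aromatic ring of carbon only, part of a fused or bridged system of two rings. No measurement available here accounts for the size of this step.

From the compounds shown here alone, whether the lower number belongs to nitro specifically or to substitution at this carbon more generally stays open, and an amine, a methoxy group or a carboxylic acid at the same place would separate those two readings. Also open, going by these compounds, is whether nitro gives a step of similar size on compound 1, which carries no chloro.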